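Pyridine for pyrazole on a core without a measured potency

The compounds below may be only part of what the source reports. "The series", "measured", "known", "first", "only" and "open" are said of these compounds alone.

In a functional assay on NCI-H1993 cells (Homo sapiens) for inhibition, read by CCK-8 assay, with a stated time of 72 h (a lower number here means a stronger inhibitor, a higher number a weaker inhibitor), compound 1 (`Cc1nc2ncc(-c3cnn(C)c3)nc2n1Cc1ccc2ncccc2c1`) gives > 10000 nM, which is a limit of the assay and not a number. Compound 2 (`Cn1cc(-c2cnc3nc(O)n(Cc4ccc5ncccc5c4)c3n2)cn1`), with hydroxy in place of methyl on an aromatic carbon, gives > 10000 nM, and this too is a limit. Compound 2 therefore has no exact position on the scale, and the picture so far is the limit of > 10000 nM in this assay, at which 2 of the 2 values shown sit.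

Compound 3 (`Oc1nc2ncc(-c3ccncc3)nc2n1Cc1ccc2ncccc2c1`) has the same hydroxy group as compound 2 but changes one other group, with pyridin-4-yl in place of 1-methyl-1H-pyrazol-4-yl on an aromatic carbon. Within the data shown here, the only measured step is a step that the two limits leave unreadable from compound 1 to compound 2. It concerns a different group and has no readable size, so it offers no size to carry over to this change. With no measured sign of a shift, compound 3 is expected to stay near compound 2, which gives > 10000 nM. The expected change is a number no higher from compound 2 to compound 3 (the limit leaves the size open), so no step beyond the scatter is anticipated. For compound 3 the estimated half-maximal inhibitory concentration is 10000 nM, with an expected range of 3000 nM to 30000 nM.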

Compound 3, half-maximal inhibitory concentration: > 10000 nM
Compound 3 was reported as a limit (the forecaster's own chance of this, stated with the estimate: 80%); the middle value lies on the limit itself.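

Among these compounds, compound 2 and compound 3 both stand as limits of the assay and not as numbers, so the change from 1-methyl-1H-pyrazol-4-yl to pyridin-4-yl gives no step that can be read. The compounds shown leave open how far any of these changes shifts potency, because all of them sit at the same point: the limit of > 10000 nM in this assay, at which 3 of the 3 values shown sit.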